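The source may hold more compounds than are shown below. What is called first, only, known or untested is meant among the compounds shown, and "the series" means these compounds.

In a toxicity assay on KB cells (Homo sapiens) for cytotoxicity, read by fluorescence, with a stated time of 3 days (a lower number here means that less compound is needed, a higher number that more compound is needed for the effect), compound 1 `CCCCOC(=O)CNC(=O)[C@H](CSc1ccc([N+](=O)[O-])cc1[N+](=O)[O-])NC(=O)CC[C@H](NC(=O)CC(C)(C)C)C(=O)OCCCC` gives 250 uM. Compound 2 `CCCCOC(=O)CNC(=O)[C@H](CSc1ccc([N+](=O)[O-])cc1[N+](=O)[O-])NC(=O)CC[C@H](N)C(=O)OCCCC` gives 107 uM. Compound 3 `CCCCCCCCCCCCCC(=O)N[C@@H](CCC(=O)N[C@@H](CSc1ccc([N+](=O)[O-])cc1[N+](=O)[O-])C(=O)NCC(=O)OCCCC)C(=O)OCCCC` gives only a limit of the assay, > 300 uM.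

The account follows the step from compound 3 to compound 4 `CCCCOC(=O)CNC(=O)[C@H](CSc1ccc([N+](=O)[O-])cc1[N+](=O)[O-])NC(=O)CC[C@H](NC(=O)CCC(C)C)C(=O)OCCCC`. Compound 3 stands at the upper edge of the numbers shown, where one of the three values sits (the limit of > 300 uM in this assay, at which 1 of the 3 values shown sits), so its true value is not known. The change is isopropyl in place of undecyl on a saturated chain carbon, two bonds along the chain from a carbonyl carbon. The measured step that bears on it is an at least 1.2-fold higher number from compound 1 to compound 3 (0.07 log units; that floor lies within the scatter), whose floor lies within the scatter; a 2.3-fold lower number from compound 1 to compound 2 (0.37 log units; beyond the scatter) concerns a different position. Compound 4 is therefore expected to land near compound 1 in this assay, and compound 4 is estimated at 220 uM (range 100 uM to 400 uM), an expected step of an at least 1.3-fold lower number from compound 3 to compound 4 (0.13 log units; that floor lies within the scatter) whose size is uncertain because the starting point is only a limit.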

Compound 4, concentration for half-maximal effect: 84 uM
For compound 4 the middle estimate is 2.6-fold (0.42 log units) above the measured one; the whole stated range lies above it.
By their numbers in this assay, from the lowest: compounds 4 and 2 (each within the scatter of the next); then compound 1. At a limit, above all of these: compound 3.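

Compound 3 stands at a limit in this assay: the limit of > 300 uM in this assay, at which 1 of the 4 values shown sits. Isopropyl in place of undecyl gives an at least 3.5-fold lower number from compound 3 to compound 4 (0.55 log units; beyond the scatter), and isobutyl in place of tert-butyl gives a 3.0-fold lower number from compound 1 to compound 4 (0.47 log units; beyond the scatter), so the number at this position shifts with the branching of the chain, not only with its length. Isopentylcarbonyl in place of hydrogen on the amine nitrogen gives a 1.3-fold lower number from compound 2 to compound 4 (0.11 log units; within the scatter), so this acyl group, unlike the neopentylcarbonyl of compound 1, leaves the number level with the free amine. The compounds shown leave open whether a hexyl chain, or a chain ending in a carboxylic acid, would stay level with compound 4.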